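Benzoxazole sulfonamides: tolerated concentration in a cell assay

The source may report more compounds than this note shows. Statements on the series, on what has been measured and on what is new or still open speak of the compounds shown alone.

Measured so far in an ADME assay on HEK293 cells (Homo sapiens) for cytotoxicity, read by resazurin assay, with a stated time of 48 h; a higher number here means that more compound is tolerated, a lower number that less compound is tolerated:
Compound 1 `Cc1cccc(S(=O)(=O)Nc2ccc3oc(-c4ccccc4)nc3c2)c1` gives 69000 nM.
Compound 2 `O=S(=O)(Nc1ccc(-c2nc3ccccc3o2)cc1)c1ccccc1F` gives only a limit, > 100000 nM.
Compound 3 `O=S(=O)(Nc1ccc(-c2nc3ccccc3o2)cc1)c1cccc(F)c1` gives only a limit, > 100000 nM.

For the measured compounds named here, compound 1 holds the only number in this assay; the other two values are limits. The step that the two limits leave unreadable from compound 2 to compound 3 cannot be read, since both ends sit at the limit, which is where most of the series stands (the limit of > 100000 nM in this assay, at which 2 of the 3 values shown sit).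

Compound 4 `O=S(=O)(Nc1ccc2oc(-c3ccccc3)nc2c1)c1ccccc1F` is not yet measured. The change from compound 1 is 2-fluorophenyl in place of 3-methylphenyl on a sulfonyl sulfur. Going by the values given here, no measured step bears directly on it, and the only readable value is that of compound 1. Compound 4 is therefore expected near the limit, with a 1.4-fold higher number from compound 1 to compound 4 (0.16 log units; within the scatter) as the estimated step, giving 100000 nM with a range of 50000 nM to 200000 nM.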

Compound 4, half-maximal cytotoxic concentration: 72000 nM
Compound 4: the middle estimate sits 1.4-fold (0.14 log units) above what was measured; the range from low to high includes it.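

For the compounds shown here, replacing 3-methylphenyl with 2-fluorophenyl on a sulfonyl sulfur gives a 1.0-fold higher number from compound 1 to compound 4 (0.02 log units; within the scatter) in this assay, the first readable step. On the core of compound 1, the two groups therefore cannot be told apart at this position.

Going by these compounds, whether a carboxylic acid or an aliphatic amine on the sulfonyl sulfur would move the value away from that of compound 1 remains open. Much of the series still gives no number: the limit of > 100000 nM in this assay, at which 2 of the 4 values shown sit.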